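Thiadiazole in Place of Oxadiazole at the Shared Sulfur

The source may hold more compounds than are shown below. What is called first, only, known or untested is meant among the compounds shown, and "the series" means these compounds.

Compound 1 `Cc1nnc(SCc2cc(=O)c3cc(Cl)ccc3o2)o1` was examined in a functional assay on HEp-2 cells (Homo sapiens) for cytotoxicity, read by MTT assay, with a stated time of 72 h; on this read-out lower numbers stand for stronger inhibition and higher numbers for weaker inhibition. In this assay compound 1 gives only a limit, > 25000 nM. Compound 2 `Cc1nnc(SCc2cc(=O)c3ccccc3o2)o1` in this assay likewise gives a limit, > 25000 nM. Compound 3 `Cc1cc(C)nc(SCc2cc(=O)c3ccccc3o2)n1` in this assay also gives a limit, > 25000 nM. Among the compounds with values here, the one step between measured neighbours, a step that the two limits leave unreadable from compound 1 to compound 2, cannot be read between two limits. Every value shown sits at the limit of > 25000 nM in this assay, at which 3 of the 3 values shown sit, so compound 1 stands nowhere apart from the others. Compound 4 `Cc1nnc(SCc2cc(=O)c3cc(Cl)ccc3o2)s1` differs from compound 1 by 5-methyl-1,3,4-thiadiazol-2-yl in place of 5-methyl-1,3,4-oxadiazol-2-yl on a sulfur. Within the data shown here, no measured step bears on this change, and the single step measured gave no readable size. Compound 4 is therefore expected to give about 35000 nM, within a range from 12000 nM to 100000 nM, most probably again only a limit. For compound 4 this estimate means a step that the limit leaves unreadable from compound 1 to compound 4, no step beyond the scatter.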

Compound 4, half-maximal inhibitory concentration: > 25000 nM
Compound 4: no number, only a limit; the forecaster's own chance of this, stated with the estimate: 85%; the middle value is on the limit's open side.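

Compound 1 and compound 4 each give only a limit, so no step between them can be read: the limit of > 25000 nM in this assay, at which 4 of the 4 values shown sit.

The compounds shown leave open how 5-methyl-1,3,4-thiadiazol-2-yl and 5-methyl-1,3,4-oxadiazol-2-yl compare in this assay.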